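The source may hold more compounds than are shown below. What is called first, only, known or untested is meant among the compounds shown, and "the series" means these compounds.

Compound 1 `COc1cccc(C(=O)N(C)/N=C/c2ccc(OC)c(OC)c2)c1` gives 73% in a functional assay on the whole organism (lung, strain A/J) for inhibition, with Mus musculus as the target, with stated times of 1 h and 18 h, at a dose of 100 umol/kg by the oral route; on this read-out lower numbers stand for less inhibition and higher numbers for more inhibition at the one dose given (going by the name of the read-out). Compound 2 `COc1ccc(/C=N/N(C)C(=O)c2ccccc2)cc1OC`, which carries hydrogen in place of methoxy on an aromatic carbon, gives 73% in this assay, so the step of no change at the digits printed from compound 1 to compound 2 (within the scatter) lies within the scatter, and compound 1 stands level with compound 2 at the digits shown; the series so far offers no compound from which compound 1 is separated beyond the scatter.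

Compound 3 `COc1ccc(/C=N/N(C)C(=O)c2ccc(Cl)cc2)cc1OC` has not yet been measured in this assay. It differs from compound 1 in this way: 4-chlorophenyl in place of 3-methoxyphenyl on a carbonyl carbon. Within the data shown here, the only step bearing on this change is no change at the digits printed from compound 1 to compound 2 (within the scatter), which removed the same methoxy group and moved the read-out by nothing beyond the scatter. Among the measured compounds shown here, the chlorine that enters has no precedent among the measured compounds, so its contribution is unknown. The expectation is therefore a step of a number 3 percentage points lower from compound 1 to compound 3 (within the scatter) of no size beyond the scatter, with a wider range to cover the untested chlorine. Compound 3 is estimated at 70% in this assay, expected between 50% and 85%.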

Compound 3, a percentage reported as inhibition, in the whole organism at one dose (the size of the read-out at that dose, not a potency): 69%
Estimate against measurement, compound 3: 1 percentage points above; the measured number falls inside the stated range.
By their numbers in this assay, from the lowest: compounds 3, 1 and 2 (each within the scatter of the next).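

Within this assay, chloro in place of hydrogen on an aromatic carbon gives a number 4 percentage points lower from compound 2 to compound 3 (within the scatter), the first evidence on a substituent other than methoxy on this aryl group. The exchange of 3-methoxyphenyl for 4-chlorophenyl on a carbonyl carbon gives a number 4 percentage points lower from compound 1 to compound 3 (within the scatter), so the read-out does not separate compound 3 from either compound 1 or compound 2, and none of the three aryl groups on this carbonyl carbon stands apart from the others beyond the scatter. The data offer no measurement that could account for these compounds staying together.

On these data alone, an amine or a carboxylic acid in place of the chloro remains open, and only such a group, unlike the chloro and methoxy compared so far, would test whether this aryl group can carry a substituent of another kind without the read-out leaving the scatter. The read-out also comes from one dose and is not a potency, so compound 1, compound 2 and compound 3 could still differ at lower doses, and whether this close grouping holds there cannot be judged from the present values.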